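The compounds below may be only part of what the source reports. "The series", "measured", "known", "first", "only" and "open" are said of these compounds alone.

Working notes on the series in a functional assay on HeLa S3 cells (Homo sapiens) for antiproliferative activity, read by XTT assay, with a stated time of 72 h; a lower number here means a stronger inhibitor, a higher number a weaker inhibitor. Compound 1 `C#Cc1cn([C@@H]2O[C@H](CO)[C@@H](O)[C@H]2O)c2ncnc(NC)c12` gives > 20000 nM, which is a limit of the assay and not a number. Compound 2 `Cc1ncnc2c1c(-c1ccoc1)cn2[C@@H]1O[C@H](CO)[C@@H](O)[C@H]1O` gives > 20000 nM, again a limit. Within the data shown here, compound 3 `Cc1ncnc2c1c(-c1ccsc1)cn2[C@@H]1O[C@H](CO)[C@@H](O)[C@H]1O` gives 14300 nM, the only true number so far in this assay.

The next compound, compound 4 `C#Cc1cn([C@@H]2O[C@H](CO)[C@@H](O)[C@H]2O)c2ncnc(C)c12`, changes one group: ethynyl in place of thiophen-3-yl on an aromatic carbon. In words, ethynyl stands in place of thiophen-3-yl on an aromatic carbon.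

Among the measured compounds shown here, the single measured step, an at least 1.3-fold lower number from compound 2 to compound 3 (0.14 log units; that floor lies within the scatter), exchanges one five-membered aromatic ring for another and does not get beyond the scatter. It offers little guidance on losing the ring altogether. Compound 1 also carries the ethynyl, but it differs from compound 4 in the other substituent on the core, and its result is only a limit.

For the measured compounds named here, no measured step replaces a ring with ethynyl, so the data favour no direction, and a result reported only as a limit is about as likely as a number. The expected result is a 1.2-fold lower number from compound 3 to compound 4 (0.08 log units; within the scatter), with no shift beyond the scatter anticipated. For compound 4 the estimated value is 12000 nM, with an expected range of 2500 nM to 30000 nM.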

Compound 4, half-maximal inhibitory concentration: 14700 nM
Compound 4: middle estimate off by 1.2-fold (0.09 log units), on the low side, within the range that was stated.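

In this assay, ethynyl on this aromatic carbon in place of thiophen-3-yl gives a 1.0-fold higher number from compound 3 to compound 4 (0.01 log units; within the scatter), so among these two compounds the five-membered aromatic ring can give way to a group with no ring and the read-out stays within the scatter. Two further comparisons start from a limit of the assay and not a number: the change from furan-3-yl gives an at least 1.3-fold lower number from compound 2 to compound 4 (0.13 log units; that floor lies within the scatter), and methyl in place of methylamino on an aromatic carbon gives an at least 1.3-fold lower number from compound 1 to compound 4 (0.13 log units; that floor lies within the scatter). Both are bounded on one side only, and their true size stays unread: the limit of > 20000 nM in this assay, at which 2 of the 4 values shown sit.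

Open, as far as these compounds go, is whether a carboxylic acid, an aminomethyl group or a longer chain such as propyl on this same aromatic carbon would move the number beyond the scatter in either direction, given that the thiophen-3-yl and ethynyl groups give no separation. Also open, from the compounds shown here alone, is how far the methylamino group on the core of compound 1 truly stands from the methyl of compound 4, and whether a primary amine at that place would give a number rather than a limit.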